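The source may report more compounds than this note shows. Statements on the series, on what has been measured and on what is new or still open speak of the compounds shown alone.

Measured in a functional assay on U-251 cells (Homo sapiens) for antiproliferative activity, read by MTT assay, with a stated time of 48 h; a higher number here means a weaker inhibitor, a lower number a stronger inhibitor:
- compound 1 `COc1ccc(-c2nc3cccc(-c4cc(OC)c(OC)c(OC)c4)c3o2)cc1F`: 1700 nM
- compound 2 `COc1cc(-c2cccc3nc(-c4cccc(F)c4)oc23)cc(OC)c1OC`: 2900 nM
- compound 3 `COc1cc(-c2cccc3nc(-c4cccc(Cl)c4)oc23)cc(OC)c1OC`: 18500 nM

Of these three, compound 3 has the highest number, at 18500 nM, which makes it the weakest inhibitor of the set. Its steps to both of the others lie beyond the usual scatter.

The next compound, compound 4 `COc1cc(-c2cccc3nc(-c4cccc(O)c4)oc23)cc(OC)c1OC`, carries hydroxy in place of chloro on an aromatic carbon, so a 3-chlorophenyl becomes a 3-hydroxyphenyl: hydroxy in place of chloro on an aromatic carbon. Within the data shown here, no measured compound here carries a hydroxy group, so the evidence is indirect.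

The closest guide is the change at this same place on the ring, a 6.4-fold higher number from compound 2 to compound 3 (0.80 log units; beyond the scatter), where chloro stands in place of fluoro. The wider change is an 11-fold higher number from compound 1 to compound 3 (1.04 log units; beyond the scatter). Both show that compound 3 sits high and that this part of the molecule can move the number by a modest to large amount. By contrast, a 1.7-fold higher number from compound 1 to compound 2 (0.23 log units; within the scatter) shows little separating the two compounds without chloro.

Replacing the chloro is therefore expected to bring the number down in this assay, probably part of the way toward the other two compounds. The expected change is a 3.7-fold lower number from compound 3 to compound 4 (0.57 log units; beyond the scatter). For compound 4 the estimated value is 5000 nM, with an expected range of 1200 nM to 20000 nM.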

Compound 4, half-maximal inhibitory concentration: 5500 nM
Beside the measured number, compound 4's estimate is 1.1-fold (0.04 log units) below it, and the stated range covers the measured number.
By their numbers in this assay, from the lowest: compounds 1, 2 and 4 (each within the scatter of the next, the first and the last beyond it); then compound 3.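

In this assay, hydroxy in place of chloro on the aromatic carbon gives a 3.4-fold lower number from compound 3 to compound 4 (0.53 log units; beyond the scatter) and so shows that compound 3's high number does not hold for every group at this place. The step of a 1.9-fold higher number from compound 2 to compound 4 (0.28 log units; within the scatter) stays within the scatter, so hydroxy and fluoro cannot be told apart here, and among the three groups tried on this ring with no methoxy present, chloro alone stands apart. The comparison with the 3-fluoro-4-methoxyphenyl group is less level, since a 3.2-fold higher number from compound 1 to compound 4 (0.51 log units; beyond the scatter) is a modest step even though compound 2 lies within the scatter of both of those compounds, and nothing measured here says why these groups fall in this order.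

An amine, a methyl or a carboxylic acid at this same place could show whether chloro is a lone exception or one end of a wider spread of numbers. Going by these compounds, the rest of the shared core is the same in compound 3 and compound 4, so it remains open whether hydroxy in place of chloro would give a step of similar size on a different core.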